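Methyl for carboxy on the indole of compound 1

A few compounds are considered here, and "the series" means these few. Any claim that something is new, unique, unknown or untested is made for them only; others in the source may bear on it.

Compound 1 `Cn1c(=O)c(S(=O)(=O)c2ccc(F)cc2F)cc2cnc(Nc3ccc4[nH]c(C(=O)O)cc4c3)nc21` and compound 2 `O=c1c(S(=O)(=O)c2ccc(F)cc2F)cc2cnc(Nc3ccc4[nH]ccc4c3)nc2n1C1CCCC1` share a core and were both tested in a functional assay on DU-145 cells (Homo sapiens) for inhibition, read by trypan blue exclusion, with a stated time of 72 h; on this read-out lower numbers stand for stronger inhibition and higher numbers for weaker inhibition. Compound 1 gives 10000 nM in this assay. Compound 2 gives 5000 nM, so compound 1 stands as the higher of the two numbers, though the gap lies within the scatter. Compound 3 `Cc1cc2cc(Nc3ncc4cc(S(=O)(=O)c5ccc(F)cc5F)c(=O)n(C)c4n3)ccc2[nH]1` differs from compound 1 in one place: methyl in place of carboxy on an aromatic carbon. Within the data shown here, no step of this kind has been measured, so only a modest change is expected from compound 1 to compound 3, a 1.7-fold lower number from compound 1 to compound 3 (0.22 log units; within the scatter), not clearly beyond the scatter. Compound 3 is therefore estimated at 6000 nM in this assay, within 2000 nM to 20000 nM.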

Compound 3, half-maximal inhibitory concentration: 750 nM
The estimate for compound 3 lay 8.0-fold (0.90 log units) above the measured number, and the stated range ends above it.
By their numbers in this assay, from the lowest: compound 3; then compounds 2 and 1 (each within the scatter of the next).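

In this assay, putting methyl in place of carboxy on this aromatic carbon, next to the ring nitrogen, gives a 13-fold lower number from compound 1 to compound 3 (1.12 log units; beyond the scatter). Among these compounds, this is the first reading of this position, and it shows that the position is sensitive to what it carries, since compounds 1 and 2 differ in more than one place and offered no such step. No independent measurement at hand explains this step. The compounds shown leave open how an ethyl group, an amine or a methyl ester would read at this position.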